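The compounds below may be only part of what the source reports. "The series", "measured", "known", "first", "only" and "open" are said of these compounds alone.

Measured so far:
compound 1 `O=S(=O)(Nc1ccc2oc(-c3ccccc3)nc2c1)c1cccc(C(F)(F)F)c1` — > 100000 nM
compound 2 `Cc1ccc(S(=O)(=O)Nc2ccc(-c3nc4ccccc4o3)cc2)cc1` — > 100000 nM
compound 3 `CS(=O)(=O)Nc1ccc(-c2nc3cc(NS(=O)(=O)c4ccc(Cl)s4)ccc3o2)cc1` — 43000 nM

In an assay on cells for inhibition of HSP60/HSP10 (Homo sapiens), with a stated time of 60 min (a higher number here means a weaker inhibitor, a lower number a stronger inhibitor), compound 1 returns only a limit of the assay, > 100000 nM. Compound 2 likewise stops at a limit, > 100000 nM. Among the compounds with values here, compound 3 is the single member of this set with a numerical half-maximal inhibitory concentration in this assay, 43000 nM, and even that sits far toward the weak end. Within the data shown here, compound 1 therefore stands with the bulk of the set, at the limit of > 100000 nM in this assay, at which 2 of the 3 values shown sit; no measured pair here differs in one place, so no step size is known.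

Compound 4 `O=S(=O)(Nc1ccc2oc(-c3ccccc3)nc2c1)c1cccc(F)c1` is the next entry. Relative to compound 1 the change is fluoro in place of trifluoromethyl on an aromatic carbon, meta to a large group, with the shared core and the sulfonamide left untouched. With no measured step of this kind in the set, the expectation is a step of no clear direction and none beyond the usual scatter of this assay. Compound 4 is thus expected to come out at 100000 nM (range 30000 nM to 300000 nM), i.e. an estimated step of a number no higher from compound 1 to compound 4 (the limit leaves the size open), most probably reported again only as a limit.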

Compound 4, half-maximal inhibitory concentration: > 100000 nM
Compound 4: no number, only a limit (the forecaster's own chance of this, stated with the estimate: 75%); the middle value sits exactly at the limit.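

Compound 1 and compound 4 both stop at a limit in this assay, and the step between them, fluoro in place of trifluoromethyl, cannot be read: the limit of > 100000 nM in this assay, at which 3 of the 4 values shown sit.

The compounds shown leave open whether fluoro and trifluoromethyl differ at all in their effect on inhibition when carried on the shared core.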